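Benzyl for phenyl on the biphenyl amide nitrogen

This account rests on a few compounds, and the source may have more. Where it says the series, first, only, none or still open, it means among the compounds named here.

Of the compounds shown here, three have been measured in an in vitro functional assay on HEK ts201 cells for antagonist activity at Neuronal acetylcholine receptor; alpha4/beta2 (Homo sapiens), read by fluorescence and calcium flux; a higher number here means a weaker inhibitor, a lower number a stronger inhibitor. Compound 1 `CC1CC(=O)N(c2ccccc2C(=O)OCC2CCCN(CCCCCc3ccccc3)C2)C1=O` gives 24500 nM, compound 2 `O=C(Nc1ccccn1)c1ccccc1-c1ccccc1` gives 13600 nM, and compound 3 `O=C(Nc1ccccc1)c1ccccc1-c1ccccc1` gives 6900 nM. Compound 3 has the lowest of the three numbers; its nearest neighbour is compound 2, whose number is higher by an amount within the scatter, while compound 1 is further off, beyond the scatter. Among the compounds with values here, the one single-point step known so far, a 2.0-fold lower number from compound 2 to compound 3 (0.29 log units; within the scatter), changed the group on the amide-type nitrogen and stayed within the scatter.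

Compound 4 `O=C(NCc1ccccc1)c1ccccc1-c1ccccc1` is not yet measured. It differs from compound 3 in this way: benzyl in place of phenyl on an amide-type nitrogen. Within the data shown here, no measured pair shows a benzyl against a phenyl at this position, so the step from compound 2 to compound 3 is the only guide, and it was small. On that basis the author expects no change beyond the scatter from compound 3 to compound 4, a 1.2-fold higher number from compound 3 to compound 4 (0.06 log units; within the scatter). In this assay compound 4 is therefore estimated at 8000 nM, between 2500 nM and 25000 nM.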

Compound 4, half-maximal inhibitory concentration: 7500 nM
The estimate for compound 4 lay 1.1-fold (0.03 log units) above the measured number; measured number inside the range.
By their numbers in this assay, from the lowest: compounds 3, 4, 2 and 1 (each within the scatter of the next, the first and the last beyond it).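

In this assay the amide-type nitrogen accepts benzyl as readily as phenyl, with a 1.1-fold higher number from compound 3 to compound 4 (0.04 log units; within the scatter) showing that the extra carbon of benzyl leaves the number within the scatter. The step of a 1.8-fold lower number from compound 2 to compound 4 (0.26 log units; within the scatter) also stays within the scatter, so pyridin-2-yl, phenyl and benzyl on this nitrogen cannot be told apart by these numbers, and the position has so far shown no step beyond the scatter. No evidence is available to explain this flat response.

Going by these compounds, it remains open whether a longer chain such as phenethyl, or an amine or carboxylic acid on the benzyl ring, would give a step beyond the scatter. Compound 1 differs from the others in more than one place, so it says nothing about this nitrogen.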